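This account rests on a few compounds, and the source may have more. Where it says the series, first, only, none or still open, it means among the compounds named here.

In a physicochemical assay for lipophilicity, read by mass spectrometry (on this read-out lower numbers stand for lower lipophilicity and higher numbers for higher lipophilicity), compound 2 (`COc1cccc(NC(=O)C2Cc3cc(OC)c(OC)cc3C2=O)c1`) gives 2.08 and compound 1 (`COc1cc2c(cc1OC)C(=O)C(C(=O)Nc1ccccc1)C2`) gives 2.2, a step of a number 0.12 log units lower from compound 1 to compound 2 (within the scatter). Compound 3 (`CCOc1cccc(NC(=O)C2Cc3cc(OC)c(OC)cc3C2=O)c1`) gives 2.42, with a number 0.34 log units higher from compound 2 to compound 3 (beyond the scatter). Compound 4 (`COc1cc2c(cc1OC)C(=O)C(C(=O)Nc1ccccc1Br)C2`) carries 2-bromophenyl in place of 3-methoxyphenyl on an amide-type nitrogen. The closest measured evidence is a number 0.12 log units lower from compound 1 to compound 2 (within the scatter) and a number 0.22 log units higher from compound 1 to compound 3 (within the scatter), together with the step already noted for the ethoxy compound. Within the data shown here, no measured compound carries bromine, so the estimate is loose. A modest rise in this assay is expected, an estimated a number 0.42 log units higher from compound 2 to compound 4 (beyond the scatter). For compound 4 the expected value is 2.5, with an estimated range of 2.1 to 2.9.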

Compound 4, partition coefficient: 3.03
Compound 4: the middle estimate sits 0.53 log units below what was measured; the measured number lies above the stated range.
By their numbers in this assay, from the lowest: compounds 2, 1 and 3 (each within the scatter of the next, the first and the last beyond it); then compound 4.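

On the ring carried by the amide-type nitrogen, bromo in place of hydrogen gives the first step from compound 1 in this assay that lies beyond the scatter (a number 0.83 log units higher from compound 1 to compound 4 (beyond the scatter)), whereas the methoxy and ethoxy steps from compound 1 stayed within it. Replacing 3-methoxyphenyl with 2-bromophenyl gives a step of similar standing (a number 0.95 log units higher from compound 2 to compound 4 (beyond the scatter)). Nothing measured accounts for the size of these steps. From the compounds shown here alone, whether chloro, an amine or a carboxylic acid in place of hydrogen on that ring would move the number as bromo does remains open. Also open, going by these compounds, is whether bromo elsewhere on the ring would give the same step.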